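Methyl at the ring nitrogen: pyridine amidrazone thiosemicarbazides

A few compounds are considered here, and "the series" means these few. Any claim that something is new, unique, unknown or untested is made for them only; others in the source may bear on it.

Measured compounds in a functional assay on A-375 cells (Homo sapiens) for cytotoxicity, read by MTT assay, with a stated time of 72 h, tested at 100 uM; on this read-out lower numbers stand for less inhibition of growth and higher numbers for more inhibition of growth at the one concentration tested:
- compound 1 `N/C(=N\NC(=S)N1CCOCC1)c1ccccn1` gives 14%
- compound 2 `Cc1ccnc(/C(N)=N/NC(=S)N2CCOCC2)c1` gives 90.6%
- compound 3 `N/C(=N\NC(=S)N1CCCCC1)c1ccccn1` gives 88.5%

Compound 1 stands lowest of the three numbers in this assay; its nearest neighbour is compound 3, and compound 2 lies furthest from it, both beyond the scatter. The step to compound 4 `Cc1cccc(/C(N)=N/NC(=S)N2CCOCC2)n1` is methyl in place of hydrogen on an aromatic carbon; the methyl enters on an aromatic carbon of a six-membered aromatic ring with one nitrogen, next to the ring nitrogen and meta to a large group.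

Among the compounds with values here, two measured steps bear on this. The closest in kind is the methyl step a number 76.6 percentage points higher from compound 1 to compound 2 (beyond the scatter), though that methyl sits at a different place on the ring. The other change from compound 1, a number 74.5 percentage points higher from compound 1 to compound 3 (beyond the scatter), shows that a single small change at either end of the shared core can move this assay by a large amount. A rise is therefore expected for compound 4, with its size uncertain; the estimated step is a number 51 percentage points higher from compound 1 to compound 4 (beyond the scatter). Compound 4 is expected to give about 65%, in the range 20% to 95%.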

Compound 4, percent growth inhibition at one concentration: 83.8%
Estimate against measurement, compound 4: 18.8 percentage points below, within the range that was stated.
By their numbers in this assay, from the lowest: compound 1; then compounds 4, 3 and 2 (each within the scatter of the next).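

In this assay, within the data shown here, methyl in place of hydrogen on the aromatic carbon next to the ring nitrogen gives a number 69.8 percentage points higher from compound 1 to compound 4 (beyond the scatter), so this position also carries a large step, which the earlier compounds did not show. Compound 2, with its methyl at a different place on the ring, gives 90.6% and compound 4 gives 83.8%; these values lie within the scatter of each other, so this assay does not tell the two ring places apart. No measurement at hand accounts for this step.

Open, going by these compounds, is whether a different group on this carbon, such as ethyl, methoxy or an amine, would give a similar value. Also open, on these data alone, is how methyl at this position behaves with piperidin-1-yl in place of morpholin-4-yl, the change found in compound 3.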